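A few compounds are considered here, and "the series" means these few. Any claim that something is new, unique, unknown or untested is made for them only; others in the source may bear on it.

Measured in a functional assay on OVCAR-5 cells (Homo sapiens) for inhibition, read by CCK-8 assay, with a stated time of 72 h, tested at 10 uM; on this read-out higher numbers stand for more inhibition of growth at the one concentration tested and lower numbers for less inhibition of growth:
compound 1 `CN(C)C(=O)c1cc2cnc(Nc3ccc(NC(=O)C4(C(=O)Nc5cccc(Cl)c5)CC4)cc3)nc2n1C1CCCC1`: 88.1%
compound 2 `CN(C)C(=O)c1cc2cnc(Nc3ccc(NC(=O)C4(C(=O)Nc5ccc(Br)cc5)CC4)cc3)nc2n1C1CCCC1`: 87.8%
compound 3 `Nc1ccc(NC(=O)C2(C(=O)Nc3ccc(F)cc3)CC2)cc1F`: 9.7%

Compound 2 stands level with compound 1, the two lying within the scatter of each other, and far over compound 3. Next is compound 4 `CN(C)C(=O)c1cc2cnc(Nc3ccc(NC(=O)C4(C(=O)Nc5ccc(O)cc5)CC4)cc3)nc2n1C1CCCC1`, with this difference: hydroxy in place of bromo on an aromatic carbon. In words, hydroxy in place of bromo on an aromatic carbon. Among the measured compounds shown here, the only measured step bearing on this position is a number 0.3 percentage points lower from compound 1 to compound 2 (within the scatter), which is very small. For the measured compounds named here, it exchanges one halogenated phenyl for another, and no measured step brings in a hydroxy, so the guide is weak. The expected step is a number 7.8 percentage points lower from compound 2 to compound 4 (within the scatter), a small fall in this assay. The estimate for compound 4 is 80%, with an expected range of 60% to 93%.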

Compound 4, percent growth inhibition at one concentration: 90.9%
Compound 4: the middle estimate sits 10.9 percentage points below what was measured; the range from low to high includes it.
By their numbers in this assay, from the lowest: compound 3; then compounds 2, 1 and 4 (each within the scatter of the next).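

Readings in this assay show a number 3.1 percentage points higher from compound 2 to compound 4 (within the scatter) for hydroxy replacing bromo and a number 2.8 percentage points higher from compound 1 to compound 4 (within the scatter) for 4-hydroxyphenyl replacing 3-chlorophenyl. Among the compounds shown here, a non-halogen group on this phenyl ring therefore stands level with the two halogenated phenyl groups, which the earlier compounds alone could not show. Nothing at hand gives a reason for this level result. Still open, as far as these compounds go, is whether an amine or a carboxylic acid in the same place on the ring would hold this level. Also open, from the compounds shown here alone, is whether compound 1, compound 2 and compound 4 would separate at lower concentrations.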